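Aryl sulfone variation at a glutamate receptor

The source may hold more compounds than are shown below. What is called first, only, known or untested is meant among the compounds shown, and "the series" means these compounds.

In an assay on isolated protein for displacement of a labelled ligand from metabotropic glutamate receptor 5 (Homo sapiens), with a stated time of 60 min, tested at 1 uM (a higher number here means more inhibition at the concentration tested (going by the name of the read-out), a lower number less inhibition), three compounds have been measured:
compound 1 `Cc1ccc(S(=O)(=O)c2cnc3cc(F)ccc3c2N2CCC(C)CC2)cc1Cl` gives 93%;
compound 2 `CC1CCN(c2c(S(=O)(=O)c3ccc(Cl)cc3)cnc3cc(F)ccc23)CC1` gives 90%;
compound 3 `CC1CCN(c2c(S(=O)(=O)c3ccc(F)c(F)c3)cnc3cc(F)ccc23)CC1` gives 94%.

Compound 3 holds the highest of the three numbers, yet its steps to the others are within the scatter: a number 1 percentage points higher from compound 1 to compound 3 (within the scatter) and a number 4 percentage points higher from compound 2 to compound 3 (within the scatter). Compound 4 `Cc1ccc(S(=O)(=O)c2cnc3cc(F)ccc3c2N2CCC(C)CC2)cc1F` is not yet measured. It differs from compound 3 by methyl in place of fluoro on an aromatic carbon. Among the measured compounds shown here, the steps that bear on this, a number 3 percentage points lower from compound 1 to compound 2 (within the scatter), a number 1 percentage points higher from compound 1 to compound 3 (within the scatter) and a number 4 percentage points higher from compound 2 to compound 3 (within the scatter), all swap substituents on the same ring of the sulfone and all lie within the scatter. A step within the scatter is therefore expected for compound 4, a number 2 percentage points lower from compound 3 to compound 4 (within the scatter). Compound 4 is estimated at 92%, between 84% and 99%.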

Compound 4, a percentage reported as inhibition, at one concentration (the size of the read-out at that concentration, not a potency): 89%
Estimate against measurement, compound 4: 3 percentage points above; measured number inside the range.
By their numbers in this assay, from the lowest: compounds 4, 2, 1 and 3 (each within the scatter of the next).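

In this assay, methyl in place of fluoro on this aromatic carbon gives a number 5 percentage points lower from compound 3 to compound 4 (within the scatter), so the change to a carbon substituent at this place is not told apart from fluoro. The other two new steps, a number 1 percentage points lower from compound 2 to compound 4 (within the scatter) and a number 4 percentage points lower from compound 1 to compound 4 (within the scatter), are no larger, and fluoro, chloro and methyl on this ring remain indistinguishable here. No evidence bears on a cause for these small steps.

As far as these compounds go, whether methoxy, an amine or a carboxylic acid at this place would give a step beyond the scatter stays open. Readings at one concentration also leave the potency order of these four compounds open.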